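The source may hold more compounds than are shown below. What is called first, only, known or untested is meant among the compounds shown, and "the series" means these compounds.

Measured so far in a physicochemical assay for solubility; a higher number here means a more soluble compound, a lower number a less soluble compound:
- compound 1 `O=C(c1cccc(Cl)c1)N1CCC(NS(=O)(=O)c2cc(S(=O)(=O)c3ccccc3)ccc2C(F)(F)F)CC1` gives 6300 nM
- compound 2 `CN(C)c1ccc(C(=O)N2CCC(NS(=O)(=O)c3cc(S(=O)(=O)c4ccccc4)ccc3C(F)(F)F)CC2)cc1` gives 50000 nM
- compound 3 `O=C(c1ccc(Cl)nc1)N1CCC(NS(=O)(=O)c2cc(S(=O)(=O)c3ccccc3)ccc2C(F)(F)F)CC1` gives 25000 nM

Compound 3 stands level with compound 2 within the scatter (a 2.0-fold lower number from compound 2 to compound 3 (0.30 log units; within the scatter)) and clearly higher than compound 1 (a 4.0-fold higher number from compound 1 to compound 3 (0.60 log units; beyond the scatter)). It therefore belongs to the upper part of this small set.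

The next compound is compound 4 `O=C(O)c1ccc(N2CCC(NS(=O)(=O)c3cc(S(=O)(=O)c4ccccc4)ccc3C(F)(F)F)CC2)cc1`, which has 4-carboxyphenyl in place of (6-chloropyridin-3-yl)carbonyl on an amine nitrogen in a ring. The measured steps bear on this change only loosely. Going by the values given here, all of them are swaps on a carbonyl carbon, none alters the group on the amine nitrogen, and no measured compound carries 4-carboxyphenyl. Even so, the largest of these steps is modest (a 7.9-fold higher number from compound 1 to compound 2 (0.90 log units; beyond the scatter)), and the step to compound 3 is of similar standing (a 4.0-fold higher number from compound 1 to compound 3 (0.60 log units; beyond the scatter)). These two steps set the size to expect here.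

A modest upward step is expected in this assay (a 2.5-fold higher number from compound 3 to compound 4 (0.40 log units; beyond the scatter)), although its direction is a judgement without a measured precedent in the series. For compound 4 the estimated value is 63000 nM (expected range 20000 nM to 200000 nM).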

Compound 4, solubility: 25000 nM
Compound 4: middle estimate off by 2.5-fold (0.40 log units), on the high side; the measured number falls inside the stated range.
By their numbers in this assay, from the lowest: compound 1; then compounds 3, 4 and 2 (each within the scatter of the next).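

In this assay, the amine nitrogen in the ring need not carry a carbonyl-linked group: 4-carboxyphenyl in place of (6-chloropyridin-3-yl)carbonyl leaves the read-out level (no change at the digits printed from compound 3 to compound 4 (within the scatter)), and the same holds against (4-(dimethylamino)phenyl)carbonyl (a 2.0-fold lower number from compound 2 to compound 4 (0.30 log units; within the scatter)). Against (3-chlorophenyl)carbonyl, the swap lies beyond the scatter (a 4.0-fold higher number from compound 1 to compound 4 (0.60 log units; beyond the scatter)), so compound 1 stands apart from compounds 2, 3 and 4, and a change on the amine nitrogen reaches the same band as the earlier swaps on the carbonyl carbon. No measurement at hand accounts for these two kinds of change arriving at the same level.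

The compounds shown leave open whether the number for compound 4 goes with the carboxylic acid or with an aromatic ring bound directly to the amine nitrogen; a methyl ester or a primary amide in place of the acid, or the acid on a carbonyl-linked phenyl, would separate the two. Also open, as far as these compounds go, is whether a non-aromatic group on this nitrogen, such as a short alkyl chain bearing an amine, stays in the same band.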